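The compounds below may be only part of what the source reports. "The series", "measured", "known", "first", "only" and "open" are said of these compounds alone.

Of the compounds shown here, three built on one shared core have been tested in an assay on isolated protein with Bile acid receptor (Homo sapiens) as the target; a lower number here means that less compound is needed, a higher number that more compound is needed for the effect. Compound 1 `COC(=O)/C=C/c1cccc(N(Cc2ccc(/C=C/c3cccc(C(F)(F)F)c3)cc2)C(=O)NC(C)C)c1` gives 932 nM. Compound 2 `COC(=O)/C=C/c1cccc(N(Cc2ccc(-c3ccc(F)c(F)c3)cc2)C(=O)C2CCCCC2)c1` gives 72 nM, the lowest of the two numbers available, and its nearest neighbour is compound 1, whose number lies well beyond the usual scatter above it. For compound 3 `COC(=O)/C=C/c1cccc(N(Cc2ccccc2Br)C(=O)C2CCCCC2)c1` only a limit is known, > 1000 nM, which is the limit of > 1000 nM in this assay, at which 1 of the 3 values shown sits, so no number can be set against it.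

Compound 4 `CCOC/C=C/c1ccc(CN(C(=O)C2CCCCC2)c2cccc(/C=C/C(=O)OC)c2)cc1` has not yet been measured. Relative to compound 2 it carries 3-ethoxyprop-1-en-1-yl in place of 3,4-difluorophenyl on an aromatic carbon. The group that leaves is an aromatic ring; the group that enters is an open chain with a double bond and an oxygen. For the measured compounds named here, no pair of measured compounds differs in just this one place, so the size of the effect is open. With compound 1 at 932 nM showing that changes at this end of the molecule can move the number well beyond the scatter, a weaker result is expected, with the step of a 5.6-fold higher number from compound 2 to compound 4 (0.74 log units; beyond the scatter). Compound 4 is therefore estimated at 400 nM, most likely between 100 nM and 1500 nM.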

Compound 4, half-maximal effective concentration: 198000 nM
Estimate against measurement, compound 4: 500-fold (2.69 log units) below; the measured number lies above the stated range.
By their numbers in this assay, from the lowest: compound 2; then compound 1; then compound 4.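

In this assay, for the compounds shown here, this is the first step that changes only the group on the aromatic carbon para to a large group, and it amounts to a 2800-fold higher number from compound 2 to compound 4 (3.44 log units; beyond the scatter). Going by these compounds alone, compound 1 differs from compound 2 in more than one place, so only this new pair isolates the position and shows how strongly the number responds to what sits there. Replacing the 3,4-difluorophenyl ring with the open 3-ethoxyprop-1-en-1-yl chain is far from a neutral swap, yet nothing measured here explains why the number rises so far.

From the compounds shown here alone, whether the loss of the aromatic ring or the arrival of the chain's oxygen matters more remains open. An all-carbon hex-1-en-1-yl chain or a plain phenyl ring at this position would help separate the two.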